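The compounds below may be only part of what the source reports. "The series", "measured", "known", "first", "only" and "open" are said of these compounds alone.

Measured compounds in an assay on isolated protein for inhibition of histone deacetylase 8 (Homo sapiens), with a stated time of 1 h; a lower number here means a stronger inhibitor, a higher number a weaker inhibitor:
- compound 1, `Cc1ccc(NC(=O)COc2ccc3cc(/C=C4/SC(=O)NC4=O)ccc3c2)cc1`: 9000 nM
- compound 2, `O=C(COc1ccc2cc(/C=C3/SC(=O)NC3=O)ccc2c1)Nc1ccc(F)cc1F`: its result is a limit of the assay, > 50000 nM
- compound 3, `O=C(COc1ccc2cc(/C=C3/SC(=O)NC3=O)ccc2c1)Nc1ccccc1`: 4500 nM

Compound 3 holds the lowest of the two numbers in this assay; compound 1 is the nearest, and the gap between them, a 2.0-fold lower number from compound 1 to compound 3 (0.30 log units; within the scatter), is within the scatter. Compound 2 stands apart only as a limit (the limit of > 50000 nM in this assay, at which 1 of the 3 values shown sits).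

Compound 4, `Cc1cc(Br)ccc1NC(=O)COc1ccc2cc(/C=C3/SC(=O)NC3=O)ccc2c1`, is not yet measured. It differs from compound 3 in one place: 4-bromo-2-methylphenyl in place of phenyl on an amide-type nitrogen.

Among the measured compounds shown here, two measured steps bear on this. The methyl step, a 2.0-fold lower number from compound 1 to compound 3 (0.30 log units; within the scatter), was within the scatter, so a methyl on the aryl ring alone did not shift the number. The substituted-aryl steps were larger: an at least 5.5-fold higher number from compound 1 to compound 2 (0.74 log units; beyond the scatter) and an at least 11-fold lower number from compound 2 to compound 3 (1.04 log units; beyond the scatter), both beyond the scatter, with the substituted ring on the weaker side. For the measured compounds named here, a bromine on the ring has no precedent among the measured compounds. The expectation for compound 4 is therefore a step of a 2.0-fold higher number from compound 3 to compound 4 (0.30 log units; within the scatter), a higher number than compound 3 in this assay, of modest size and with wide uncertainty.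

Compound 4 is estimated at 9000 nM in this assay, expected between 3000 nM and 30000 nM.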

Compound 4, half-maximal inhibitory concentration: 7400 nM
For compound 4 the middle estimate is 1.2-fold (0.09 log units) above the measured one; low and high end bracket the measured number.
By their numbers in this assay, from the lowest: compounds 3, 4 and 1 (each within the scatter of the next). At a limit, above all of these: compound 2.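

In this assay, the 4-bromo-2-methylphenyl group on the amide-type nitrogen reads the same as the smaller aryl groups: a 1.6-fold higher number from compound 3 to compound 4 (0.22 log units; within the scatter) and a 1.2-fold lower number from compound 1 to compound 4 (0.09 log units; within the scatter). Carrying bromine and a methyl on the ring therefore does not by itself move the number, which the earlier compounds could not show, since their only clear shift came with the substituted ring of compound 2. That ring stays the exception among the four compounds, with an at least 6.7-fold lower number from compound 2 to compound 4 (0.82 log units; beyond the scatter), so compounds 1 and 4 both go against any reading that substitution on this aryl ring in general costs activity, and the result for compound 2 is a limit of the assay: the limit of > 50000 nM in this assay, at which 1 of the 4 values shown sits.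

The compounds shown leave open whether the break at compound 2 follows from the two fluorines together or from one of them alone, and the true size of that break stays unknown while its value is a limit. Also open, on these data alone, is how an amine or a carboxylic acid on this aryl ring, or a longer chain in place of it, would read in this assay.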